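A Methyl Added Where Every Value Is a Limit

The source may report more compounds than this note shows. Statements on the series, on what has been measured and on what is new or still open speak of the compounds shown alone.

Compound 1 `Cc1ccccc1-n1nncc1CN1C(=O)C2(C(C#N)=C(N)Oc3c2c2nc4ccccc4nc2c2ccccc32)c2ccccc21`: > 50000 nM in an ADME assay on L02 cells (Homo sapiens) for antiproliferative activity, read by MTT assay, with a stated time of 48 h; on this read-out lower numbers stand for stronger inhibition and higher numbers for weaker inhibition
Compound 2 `N#CC1=C(N)Oc2c(c3nc4ccccc4nc3c3ccccc23)C12C(=O)N(Cc1cnnn1-c1ccc(F)c(Cl)c1)c1ccccc12`: > 50000 nM in this assay
Compound 3 `Cc1ccccc1-n1nncc1CN1C(=O)C2(C(C#N)=C(N)Oc3c(N)cc4nc5ccccc5nc4c32)c2ccccc21`: > 50000 nM in this assay

Each of these three values is a limit of the assay rather than a number. Compound 3 therefore has no measured position on a scale; it sits at the same limit as the other two, and nothing shows whether any one of them is weaker or stronger than another. Among the measured compounds shown here, the only single-point change among the measured compounds, a step that the two limits leave unreadable from compound 1 to compound 2, cannot be sized either, since both ends are limits (the limit of > 50000 nM in this assay, at which 3 of the 3 values shown sit).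

Compound 4 `CCc1ccccc1-n1nncc1CN1C(=O)C2(C(C#N)=C(N)Oc3c(N)cc4nc5ccccc5nc4c32)c2ccccc21` differs from compound 3 by methyl in place of hydrogen on a saturated chain carbon bound to an aromatic carbon. For the measured compounds named here, no measured step resembles this change, and the steps that exist give no readable size at all. Nothing in these data points toward a gain in potency from the added methyl, and compound 3 itself gives no number to move from. Going by the values given here, compound 4 is therefore expected to remain at the limit, a step that the limit leaves unreadable from compound 3 to compound 4 that is no real step. The estimate for compound 4 in this assay is 80000 nM, with a range from 30000 nM to 300000 nM, and the likeliest outcome is again a limit.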

Compound 4, half-maximal inhibitory concentration: 22900 nM
For compound 4 the middle estimate is 3.5-fold (0.54 log units) above the measured one; the whole stated range lies above it.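

In this assay, adding a single methyl to turn 2-methylphenyl into 2-ethylphenyl gives an at least 2.1-fold lower number from compound 3 to compound 4 (0.33 log units; beyond the scatter), so this place on the molecule can move the read-out off the limit, towards stronger inhibition. This is the first step in the set with a readable direction, showing that the saturated chain carbon bound to an aromatic carbon is a place where a small change can register, while the other step among these compounds still cannot be read. Its true size remains unknown, since only one end of the step is a number and the other end is a limit: the limit of > 50000 nM in this assay, at which 3 of the 4 values shown sit.

From the compounds shown here alone, whether a longer chain, such as propyl, or a branched group, such as isopropyl, would push the number lower still at this place remains open, as does whether a methoxy group would act as ethyl does. Also open, going by these compounds, is whether the same change from methyl to ethyl would lift the core of compound 1 off the limit, or whether this step belongs to the core of compound 3 alone.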